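This account rests on a few compounds, and the source may have more. Where it says the series, first, only, none or still open, it means among the compounds named here.

Three compounds built on one shared core have been examined in an ADME assay on C8166 cells (Homo sapiens) for cytotoxicity, read by MTT assay, with a stated time of 3 days; on this read-out lower numbers stand for higher toxicity in this test and higher numbers for lower toxicity in this test. Compound 1 `CC(C)(NC(=O)OCc1ccccc1)c1nc(O)c(O)c(C(=O)N/N=C/c2ccc(F)cc2)n1` gives 378000 nM in this assay. Compound 2 `COCCNC(=O)c1nc(C(C)(C)NC(=O)OCc2ccccc2)nc(O)c1O` gives 348000 nM. Compound 3 `COCCCNC(=O)c1nc(C(C)(C)NC(=O)OCc2ccccc2)nc(O)c1O` gives 259000 nM; this is the lowest of the three numbers shown, yet it lies within the scatter of both other values, so the three cannot be ranked. Every step among the measured compounds was small: a 1.1-fold lower number from compound 1 to compound 2 (0.04 log units; within the scatter), a 1.5-fold lower number from compound 1 to compound 3 (0.16 log units; within the scatter), and a 1.3-fold lower number from compound 2 to compound 3 (0.13 log units; within the scatter).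

Compound 4 `CC(C)(NC(=O)OCc1ccccc1)c1nc(O)c(O)c(C(=O)NCc2ccccc2Cl)n1` has not yet been measured. Compared with compound 3 it carries 2-chlorophenyl in place of 2-methoxyethyl on a saturated chain carbon bound to an amide-type nitrogen. The two steps that bear on this, from compound 1 to compound 2 and from compound 1 to compound 3, each replaced a ring-bearing group with a chain on an amide-type nitrogen and both stayed within the scatter; the change to compound 4 runs in the opposite sense, a chain leaving and an aromatic ring entering at a carbon bound to such a nitrogen. On this basis no step beyond the scatter is expected in this assay, and the estimated step is a 1.2-fold higher number from compound 3 to compound 4 (0.06 log units; within the scatter). For compound 4 the expected value is 300000 nM, with a range from 150000 nM to 600000 nM.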

Compound 4, half-maximal cytotoxic concentration: 53900 nM
Compound 4: the middle estimate sits 5.6-fold (0.75 log units) above what was measured; measured number outside the range, below it.
By their numbers in this assay, from the lowest: compound 4; then compounds 3, 2 and 1 (each within the scatter of the next).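

In this assay, for the compounds shown here, the substituent on the amide-type nitrogen now moves the number beyond the scatter for the first time: 2-chlorobenzyl in place of 3-methoxypropyl gives a 4.8-fold lower number from compound 3 to compound 4 (0.68 log units; beyond the scatter), and the comparison with the chain of compound 2 gives a step of similar size, a 6.5-fold lower number from compound 2 to compound 4 (0.81 log units; beyond the scatter). An aromatic ring in this substituent is not enough to produce such a drop, since compound 1 also carries one on its amide-type nitrogen, lies within the scatter of compound 2 and compound 3, and still shows a 7.0-fold lower number from compound 1 to compound 4 (0.85 log units; beyond the scatter). Among these four compounds, only the 2-chlorobenzyl group of compound 4 stands apart, and it goes with higher toxicity in this test.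

No evidence is available to explain this drop. The compounds shown leave open whether the step follows the chlorine or the benzyl group as a whole, and a plain benzyl group would separate the two, while a chain ending in an amine would show how far this position responds to a different kind of substituent.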